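The source may hold more compounds than are shown below. What is called first, only, known or untested is meant among the compounds shown, and "the series" means these compounds.

In a functional assay on K562 cells (Homo sapiens) for inhibition, read by fluorescence, with a stated time of 72 h (on this read-out higher numbers stand for weaker inhibition of growth and lower numbers for stronger inhibition of growth), three compounds have been measured so far. Compound 1 `CCCCCCn1cnc2c(Nc3ccc(Cl)cc3)nc(N[C@H]3CC[C@H](N)CC3)nc21` gives 2100 nM and compound 2 `COc1ccc(Cn2cnc3c(Nc4cccc(Cl)c4)nc(N[C@H]4CC[C@H](N)CC4)nc32)cc1` gives 2800 nM and these two values lie within the usual scatter of each other. Compound 3 `N[C@H]1CC[C@H](Nc2nc(Nc3ccc(O)cc3)c3ncn(C4CCCCC4)c3n2)CC1` gives 8900 nM as its number, and compound 2 stands lower than that by a gap beyond the scatter, which means stronger inhibition of growth.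

Compound 4 `CCCCn1cnc2c(Nc3cccc(Cl)c3)nc(N[C@H]3CC[C@H](N)CC3)nc21` has not been measured yet. It differs from compound 2 in one group, and the change propyl in place of 4-methoxyphenyl on a saturated chain carbon bound to an aromatic nitrogen puts propyl in place of 4-methoxyphenyl on a saturated chain carbon bound to an aromatic nitrogen. The same difference can be read as 4-methoxybenzyl to butyl.

Within the data shown here, no measured pair shows this change alone, so the guide is thin. Compound 1 also has a plain chain at that place, though it differs elsewhere too, and its 2100 nM stays within the scatter of compound 2. In this assay the estimated step of a 1.1-fold higher number from compound 2 to compound 4 (0.03 log units; within the scatter) is expected to stay within the scatter, with no clear direction. For compound 4 the estimated value is 3000 nM with an expected span from 1200 nM to 7500 nM as its likely range.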

Compound 4, concentration for 50% growth inhibition: 2000 nM
Estimate against measurement, compound 4: 1.5-fold (0.18 log units) above; the range from low to high includes it.
By their numbers in this assay, from the lowest: compounds 4, 1 and 2 (each within the scatter of the next); then compound 3.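

In this assay, among these compounds, the one pair that differs in a single place shows a 1.4-fold lower number from compound 2 to compound 4 (0.15 log units; within the scatter), so replacing 4-methoxybenzyl with butyl, on a saturated chain carbon bound to an aromatic nitrogen, gives no clear difference in growth inhibition. The aromatic ring and the oxygen of the 4-methoxyphenyl group leave with this change, so for this pair neither is needed to keep the number in the same range. No measurement of any property of these groups bears on this result.

The compounds shown leave open whether a chain ending in an amine or a carboxylic acid would keep the number in that range. They also leave open what a much longer alkyl chain, or a bare hydrogen, would do at this place.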